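Swapping the Thiazole of Compound 3 for a Thiophene

The source may report more compounds than this note shows. Statements on the series, on what has been measured and on what is new or still open speak of the compounds shown alone.

In a functional assay on A-375 cells (Homo sapiens) for antiproliferative activity (a higher number here means a weaker inhibitor, a lower number a stronger inhibitor), compound 1 (`O=C(Nc1ccc(-c2cscn2)cc1)C1CCCN(Cc2cc(F)cc(F)c2)C1`) gives 1360 nM, compound 2 (`O=C(Nc1ccc(-c2cscn2)cc1)C1CCCN(Cc2cccc(F)c2F)C1`) gives 1480 nM, and compound 3 (`O=C(Nc1ccc(-c2nccs2)cc1)C1CCCN(Cc2ccc(F)c(F)c2)C1`) gives 240 nM. That last number is the lowest of the three, and its gaps to the other two lie beyond the scatter. Compound 4 (`O=C(Nc1ccc(-c2cccs2)cc1)C1CCCN(Cc2ccc(F)c(F)c2)C1`) carries thiophen-2-yl in place of 1,3-thiazol-2-yl on an aromatic carbon. For the measured compounds named here, the only measured step, a 1.1-fold higher number from compound 1 to compound 2 (0.04 log units; within the scatter), lies within the scatter and concerns the fluorine pattern, not this ring, so it offers no direct guide. The expectation therefore starts from compound 3 at 240 nM. The expected step, a 1.3-fold higher number from compound 3 to compound 4 (0.10 log units; within the scatter), stays within the scatter. For compound 4 the estimated value is 300 nM, with an expected range of 100 nM to 900 nM.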

Compound 4, half-maximal inhibitory concentration: 390 nM
The estimate for compound 4 lay 1.3-fold (0.11 log units) below the measured number; the range from low to high includes it.
By their numbers in this assay, from the lowest: compounds 3 and 4 (each within the scatter of the next); then compounds 1 and 2 (each within the scatter of the next).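

Replacing 1,3-thiazol-2-yl with thiophen-2-yl gives a 1.6-fold higher number from compound 3 to compound 4 (0.21 log units; within the scatter) in this assay, the first step shown at this ring rather than in the fluorine pattern. On this aromatic carbon, the ring can therefore lose one hetero atom and one hydrogen-bond acceptor with no difference that stands out from the scatter. No measurement here offers an explanation for this result. As far as these compounds go, whether a phenyl or pyridine ring would behave the same way remains open. So does whether this swap gives a similar step with a different fluorine pattern.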